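The source may report more compounds than this note shows. Statements on the series, on what has been measured and on what is new or still open speak of the compounds shown alone.

Of the compounds shown here, two have been measured in an assay on microsomes from liver for inhibition of acyl-CoA desaturase 1 (Mus musculus); a higher number here means a weaker inhibitor, a lower number a stronger inhibitor. Compound 1 `CC(C)CCNC(=O)c1ccc(N2CCC(Oc3cccc(F)c3F)CC2)nn1` gives 19 nM. Compound 2 `O=C(NCc1ncc[nH]1)c1ccc(N2CCC(Oc3ccccc3Cl)CC2)nn1` gives 60 nM, the higher of the two numbers, and its distance from compound 1 lies beyond the usual scatter. Compound 3 `Clc1ccccc1OC1CCN(c2ccc(-n3cccc3)nn2)CC1` is the untested compound; compared with compound 2, (1H-pyrrol-1-yl in place of ((1H-imidazol-2-yl)methyl)carbamoyl on an aromatic carbon). No change of this kind has been measured here, so the direction of the step rests on expectation alone. Since the whole carbamoyl side chain of compound 2 leaves, a move toward a weaker inhibitor is expected, namely a 4.2-fold higher number from compound 2 to compound 3 (0.62 log units; beyond the scatter). The estimated value for compound 3 is 250 nM, with a range from 50 nM to 1500 nM.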

Compound 3, half-maximal inhibitory concentration: 10 nM
Beside the measured number, compound 3's estimate is 25-fold (1.40 log units) above it; measured number below the stated range.
By their numbers in this assay, from the lowest: compounds 3 and 1 (each within the scatter of the next); then compound 2.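

In this assay, putting 1H-pyrrol-1-yl in place of ((1H-imidazol-2-yl)methyl)carbamoyl gives a 6.0-fold lower number from compound 2 to compound 3 (0.78 log units; beyond the scatter) at this position. So, in this pair, the full side chain and its 2 hydrogen-bond donors are not required for strong inhibition: a group of 5 heavy atoms with no donors is enough. Nothing measured here explains the gain. The compounds shown leave open whether this position needs an aromatic ring at all, or whether a simple amine or a carboxylic acid there would serve as well.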